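The compounds below may be only part of what the source reports. "The series", "measured", "known", "first", "only" and "open" are said of these compounds alone.

Measured in a functional assay on Huh-7 cells (Homo sapiens) for cytotoxicity, read by MTT assay, with a stated time of 3 days; a lower number here means that less compound is tolerated, a higher number that more compound is tolerated:
- Compound 1 `OC[C@H]1O[C@@H](n2cnc3c(CSCc4ccccc4)ncnc32)[C@H](O)[C@@H]1O`: > 100000 nM, a limit
- Compound 2 `OC[C@H]1O[C@@H](n2cnc3c(COc4ccccn4)ncnc32)[C@H](O)[C@@H]1O`: > 250000 nM, a limit
- Compound 3 `CC(=O)N(Cc1ccccc1)Cc1ncnc2c1ncn2[C@@H]1O[C@H](CO)[C@@H](O)[C@H]1O`: > 100000 nM, a limit

Compound 2 stands at a limit and has no exact number. All three compounds are limits, with two at the limit of > 100000 nM in this assay, at which 2 of the 3 values shown sit, and one at the limit of > 250000 nM in this assay, at which 1 of the 3 values shown sits.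

Compound 4 `OCCSCc1ncnc2c1ncn2[C@@H]1O[C@H](CO)[C@@H](O)[C@H]1O` carries (2-hydroxyethyl)sulfanyl in place of (pyridin-2-yl)oxy, on a saturated chain carbon bound to an aromatic carbon: (2-hydroxyethyl)sulfanyl in place of (pyridin-2-yl)oxy on a saturated chain carbon bound to an aromatic carbon.

For the measured compounds named here, the one measured step bearing on this, a step that the two limits leave unreadable from compound 1 to compound 2, has no readable size. Compound 1, which has benzylsulfanyl in that place, sits at the limit of > 100000 nM.

No clear step in either direction is therefore expected in this assay. The estimated change is an at least 1.6-fold lower number from compound 2 to compound 4 (0.22 log units; that floor lies within the scatter). Compound 4 is expected at about 150000 nM, within an estimated range of 60000 nM to 300000 nM.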

Compound 4, half-maximal cytotoxic concentration: > 100000 nM
Compound 4 ended at the assay's limit (the forecaster's own chance of this, stated with the estimate: 85%); the middle value is on the limit's open side.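

Compound 1, compound 2 and compound 4 all stand at limits with no exact number, so the steps among them cannot be read. The compounds shown leave open whether swapping these groups changes the result in this assay at all.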